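Saturated Ring in Place of Phenyl on the Anilino Nitrogen

The compounds below may be only part of what the source reports. "The series", "measured", "known", "first", "only" and "open" are said of these compounds alone.

The measured compounds so far:
compound 1, `O=c1cc(-c2c[nH]c3ncccc23)nc(NC2CCCCC2)[nH]1`, 103 nM in a functional assay on HCT-116 cells (Homo sapiens) for cytotoxicity, with a stated time of 3 days; a lower number here means that less compound is needed, a higher number that more compound is needed for the effect;
compound 2, `O=c1cc(-c2c[nH]c3ncccc23)nc(Nc2ccccc2)[nH]1`, 443 nM in this assay.

Compound 2 stands at the higher of the two numbers: the shared core carries a phenyl on the ring nitrogen, and against compound 1, which carries a cyclohexyl at the same place, the change reads a 4.3-fold higher number from compound 1 to compound 2 (0.63 log units; beyond the scatter). Compound 3, `O=c1cc(-c2c[nH]c3ncccc23)nc(NC2CCOCC2)[nH]1`, is not yet measured. It differs from compound 2 in one place: oxan-4-yl in place of phenyl on a nitrogen on an aromatic ring. Within the data shown here, the only step that bears on this change is the one from compound 1 to compound 2, in which a saturated six-membered ring gave way to phenyl and the number rose; compound 3 reverses the direction of that exchange while bringing in one hetero atom. A step of roughly that size back toward a lower number is therefore expected for compound 3, that is a 2.5-fold lower number from compound 2 to compound 3 (0.39 log units; beyond the scatter). In this assay compound 3 is estimated at 180 nM, within a range from 60 nM to 550 nM.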

Compound 3, half-maximal effective concentration: 2460 nM
Compound 3: middle estimate off by 14-fold (1.14 log units), on the low side; the whole stated range lies below it.
By their numbers in this assay, from the lowest: compound 1; then compound 2; then compound 3.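

The exchange on this nitrogen does not behave as a simple choice between a saturated ring and phenyl: in this assay, oxan-4-yl in place of phenyl gives a 5.6-fold higher number from compound 2 to compound 3 (0.74 log units; beyond the scatter), so compound 2, with its aromatic ring, sits between the two compounds with saturated six-membered rings. The sharper reading comes from the pair that keeps the saturated ring, since oxan-4-yl in place of cyclohexyl gives a 24-fold higher number from compound 1 to compound 3 (1.38 log units; beyond the scatter), a step that the printed structures trace to one ring oxygen, with its single hydrogen-bond acceptor, in place of a ring carbon, and which is larger than the step from the phenyl compound. At this position, then, the identity of the atoms in the ring counts for at least as much as whether the ring is saturated, and nothing available explains why the oxygen carries this cost.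

On these data alone, what remains open is whether this cost belongs to oxygen in particular or to any hetero atom in the ring, which a piperidin-4-yl group, with its ring amine, would begin to test. Also open, as far as these compounds go, is how a hydroxyl on the cyclohexyl ring, or an open chain such as a methoxyethyl group, would read at the same nitrogen in this assay.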